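The compounds below may be only part of what the source reports. "The series", "measured", "known", "first", "only" and "open" are said of these compounds alone.

Series notes. The shared core carries an ethyl ester in compound 1 `CCOC(=O)C1=Cc2ccccc2OC1(OCc1cn(-c2ccc(F)cc2)nn1)C(F)(F)F` and a free carboxylic acid in compound 2 `O=C(O)C1=Cc2ccccc2OC1(OCc1cc(-c2ccc(F)cc2)no1)C(F)(F)F`. Within the data shown here, in a functional assay on A549 cells (Homo sapiens) for inhibition, read by MTT assay, with a stated time of 24 h (on this read-out lower numbers stand for stronger inhibition and higher numbers for weaker inhibition), compound 1 gives 7300 nM, the only number on hand. For compound 2 this assay reports only a limit, > 150000 nM, and not a number. Compound 1 therefore stands as the sole numerical point. The other result is the limit of > 150000 nM in this assay, at which 1 of the 2 values shown sits, belonging to compound 2. Among the measured compounds shown here, no step between two measured compounds is on hand, so no measured step size is available to lean on.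

Compound 3 `CCOC(=O)C1=Cc2ccccc2OC1(OCc1cn(-c2ccc(C)cc2)nn1)C(F)(F)F` is the next target. Relative to compound 1 the change is methyl in place of fluoro on an aromatic carbon, the same difference read one bond further out being 4-fluorophenyl to 4-methylphenyl. For the measured compounds named here, with no measured step in this assay to compare, the expectation is that the change from compound 1 to compound 3 moves this assay by no more than the usual scatter, in either direction. Compound 3 is accordingly estimated at 8000 nM, with a range from 3000 nM to 25000 nM. That corresponds to an expected step of a 1.1-fold higher number from compound 1 to compound 3 (0.04 log units; within the scatter) in this assay.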

Compound 3, half-maximal inhibitory concentration: 19700 nM
Estimate against measurement, compound 3: 2.5-fold (0.39 log units) below, within the range that was stated.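

In this assay, among these compounds, methyl in place of fluoro on an aromatic carbon, para to a large group, gives a 2.7-fold higher number from compound 1 to compound 3 (0.43 log units; beyond the scatter) and so provides the first measured step. This position is therefore not silent: the exchange of one heavy atom for one heavy atom, with no change in the counted hydrogen-bond donors or acceptors and no net charge on either group, is enough to move the read-out beyond the scatter, and fluoro is the group on the side of the lower number, which stands for stronger inhibition. Nothing measured among the compounds shown accounts for the size or direction of this step.

Going by these compounds, whether chloro, a methoxy group, an amine or a longer chain such as ethyl at this place would lie with fluoro, with methyl or outside both stays open, since two groups cannot show a trend. On these data alone, for compound 2 the result > 150000 nM is a limit and not a number, and that compound differs from the others in more than one place, so the contribution of the ethyl ester taken alone also stays open.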